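The source may report more compounds than this note shows. Statements on the series, on what has been measured and on what is new or still open speak of the compounds shown alone.

Of the compounds shown here, three built on a shared core have been measured in an ADME assay on NIH3T3 cells (Mus musculus) for cytotoxicity, read by MTT assay, with a stated time of 24 h; a higher number here means a weaker inhibitor, a lower number a stronger inhibitor. Compound 1 `O=C(CSc1nnc(-c2ccncc2)o1)N/N=C/c1ccc(F)cc1` gives 170000 nM in this assay. Compound 2 `O=C(CSc1nnc(-c2ccncc2)o1)N/N=C/c1ccc(O)cc1` gives 158000 nM in this assay. Compound 3 `O=C(CSc1nnc(-c2ccncc2)o1)N/N=C/c1ccccc1[N+](=O)[O-]` gives 214000 nM in this assay, the highest of the three numbers, although the gaps to its neighbours stay inside the scatter. Exchanging one group on the aromatic ring has so far moved the number little: a 1.1-fold lower number from compound 1 to compound 2 (0.03 log units; within the scatter).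

Compound 4 `O=C(CSc1nnc(-c2ccncc2)o1)N/N=C/c1ccc(O)c(O)c1` has not yet been measured in this assay. It differs from compound 3 in one place: 3,4-dihydroxyphenyl in place of 2-nitrophenyl on a carbon with a double bond to nitrogen. The nearest guide is compound 2, which already carries a single hydroxy group on that ring, and the relevant measured steps are a 1.4-fold higher number from compound 2 to compound 3 (0.13 log units; within the scatter) and a 1.3-fold higher number from compound 1 to compound 3 (0.10 log units; within the scatter), both inside the scatter. Because a 1.4-fold higher number from compound 2 to compound 3 (0.13 log units; within the scatter) was so small, a second hydroxy group is expected to leave the number roughly where compound 3 sits. The estimated step is a 1.3-fold lower number from compound 3 to compound 4 (0.13 log units; within the scatter). Compound 4 is expected to give 160000 nM in this assay, within a range from 80000 nM to 320000 nM.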

Compound 4, half-maximal inhibitory concentration: 154000 nM
For compound 4 the middle estimate is 1.0-fold (0.02 log units) above the measured one; low and high end bracket the measured number.
By their numbers in this assay, from the lowest: compounds 4, 2, 1 and 3 (each within the scatter of the next).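

In this assay a second hydroxy group on the ring gives a 1.0-fold lower number from compound 2 to compound 4 (0.01 log units; within the scatter) and so adds a group to the ring rather than exchanging one, yet the two numbers cannot be told apart. Larger exchanges on the carbon with a double bond to nitrogen also stay small, with a 1.4-fold lower number from compound 3 to compound 4 (0.14 log units; within the scatter) and a 1.1-fold lower number from compound 1 to compound 4 (0.04 log units; within the scatter) so that 3,4-dihydroxyphenyl cannot be told apart from 2-nitrophenyl or 4-fluorophenyl here. No measurement is available that would explain this flat picture.

On these data alone, all four compounds carry a substituted phenyl ring at this place, so the effect of an amine, a carboxylic acid or a longer alkyl chain on that ring remains open. As far as these compounds go, whether any change at this position can move the number beyond the scatter also remains open.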